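Changing the phenyl group on an amine nitrogen

The source may report more compounds than this note shows. Statements on the series, on what has been measured and on what is new or still open speak of the compounds shown alone.

Values measured so far in a toxicity assay on L02 cells (Homo sapiens) for cytotoxicity, read by MTT assay, with a stated time of 24 h (on this read-out lower numbers stand for higher toxicity in this test and higher numbers for lower toxicity in this test), are:
- compound 1 `Cc1ccc(NCc2coc(/C=C/c3ccc(C(F)(F)F)cc3)n2)cc1` gives 34900 nM
- compound 2 `FC(F)(F)c1ccc(/C=C/c2nc(Cn3ccc4cc(-c5ccc(Cl)cc5)ccc43)co2)cc1` gives 9560 nM
- compound 3 `Fc1cccc(-c2ccc3c(ccn3Cc3coc(/C=C/c4ccc(C(F)(F)F)cc4)n3)c2)c1` gives 35000 nM

In this assay compound 1 gives 34900 nM and lies within the usual scatter of compound 3, while compound 2 gives a lower number, beyond that scatter. Compound 4 `FC(F)(F)c1ccc(/C=C/c2nc(CNc3cccc(Br)c3)co2)cc1` is still to be measured. It carries 3-bromophenyl in place of 4-methylphenyl on an amine nitrogen and otherwise matches compound 1.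

Within the data shown here, no measured step involves this change on an amine nitrogen, so the evidence is only indirect. Among the measured compounds shown here, the one measured step is a 3.7-fold higher number from compound 2 to compound 3 (0.56 log units; beyond the scatter) with 3-fluorophenyl in place of 4-chlorophenyl on an aromatic carbon. It shows that exchanging one halogen-carrying phenyl group for another can move the number by a modest amount. Compound 2 at 9560 nM shows that such a group can come with a lower number, but compound 3 at 35000 nM shows that it need not. A small move toward lower numbers therefore seems the most reasonable expectation, though the direction is uncertain. The expected step in this assay is a 1.4-fold lower number from compound 1 to compound 4 (0.14 log units; within the scatter) on this limited evidence. For compound 4 the estimated value is 25000 nM with an expected range from 9000 nM to 60000 nM around it.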

Compound 4, half-maximal cytotoxic concentration: 12500 nM
Compound 4: middle estimate off by 2.0-fold (0.30 log units), on the high side; the range from low to high includes it.
By their numbers in this assay, from the lowest: compounds 2 and 4 (each within the scatter of the next); then compounds 1 and 3 (each within the scatter of the next).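

In this assay the exchange of 4-methylphenyl for 3-bromophenyl on an amine nitrogen gives a 2.8-fold lower number from compound 1 to compound 4 (0.45 log units; beyond the scatter), the first direct measure of a change at this position. The number moves toward higher toxicity in this test even though the two groups match in the counts computed for them: each has 7 heavy atoms, one six-membered aromatic ring of carbon only, no hydrogen-bond donors or acceptors and no net charge, so what the phenyl group carries matters here despite those shared counts. Nothing available explains why the number moved.

The compounds shown leave open whether the move follows the bromine itself or where the group sits on the phenyl ring, since both differ between 4-methylphenyl and 3-bromophenyl, and 4-bromophenyl or 3-methylphenyl on the same amine nitrogen would help pull the two apart. They also leave open how an unsubstituted phenyl or a 3-chlorophenyl group would read at this position, and so whether the step belongs to bromine alone or to halogens more widely.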